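The source may report more compounds than this note shows. Statements on the series, on what has been measured and on what is new or still open speak of the compounds shown alone.

In a functional assay on MCF7 cells (Homo sapiens) for cytotoxicity, read by MTT assay, with a stated time of 72 h (on this read-out lower numbers stand for stronger inhibition and higher numbers for weaker inhibition), three compounds have been measured:

- Compound 1 `O=C(N/N=C/c1ccc(O)cc1)Nc1cc2c(Nc3ccc(F)c(Cl)c3)ncnc2cc1O[C@H]1CCOC1`: 910 nM
- Compound 2 `COc1cc2ncnc(Nc3ccc(F)c(Cl)c3)c2cc1NC(=O)N/N=C/c1ccc([N+](=O)[O-])cc1`: 36800 nM
- Compound 3 `COc1cc2ncnc(Nc3ccc(F)c(Cl)c3)c2cc1NC(=O)N/N=C/c1ccc(O)cc1O`: 36200 nM

Compound 3 cannot be told apart from compound 2, and both numbers lie far higher than that of compound 1.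

Compound 4 `COc1cc2ncnc(Nc3ccc(F)c(Cl)c3)c2cc1NC(=O)N/N=C/c1ccc(O)cc1` is the next to be read. It differs from compound 3 as follows: hydrogen in place of hydroxy on an aromatic carbon. This is hydrogen in place of hydroxy on an aromatic carbon, turning 2,4-dihydroxyphenyl into 4-hydroxyphenyl.

Within the data shown here, only one measured step touches this end of the molecule: a 1.0-fold lower number from compound 2 to compound 3 (0.01 log units; within the scatter). It exchanged 4-nitrophenyl for 2,4-dihydroxyphenyl and stayed within the scatter. Compound 1 also carries 4-hydroxyphenyl, but it differs from compound 4 on the shared core, so it offers only a weak hint towards lower numbers. No change beyond the scatter is therefore expected in this assay.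

The expected change is a 1.4-fold lower number from compound 3 to compound 4 (0.16 log units; within the scatter).

For compound 4 the estimated value is 25000 nM, with an expected range from 8000 nM to 60000 nM.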

Compound 4, half-maximal inhibitory concentration: 28600 nM
Beside the measured number, compound 4's estimate is 1.1-fold (0.06 log units) below it, and the stated range covers the measured number.
By their numbers in this assay, from the lowest: compound 1; then compounds 4, 3 and 2 (each within the scatter of the next).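

In this assay, the hydroxy ortho to a large group can be replaced by hydrogen with no change beyond the scatter, as shown by a 1.3-fold lower number from compound 3 to compound 4 (0.10 log units; within the scatter). The 4-hydroxyphenyl group also cannot be told apart from 4-nitrophenyl, given a 1.3-fold lower number from compound 2 to compound 4 (0.11 log units; within the scatter), so these three end groups give no separation in this series. Among these compounds, with 4-hydroxyphenyl held constant, the exchange of oxolan-3-yl for methyl on the oxygen gives the only step here beyond the scatter, a 31-fold higher number from compound 1 to compound 4 (1.50 log units; beyond the scatter), and no available evidence accounts for that step.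

On these data alone, whether an amine or a carboxylic acid on this aromatic ring would also stay within the scatter remains open. As far as these compounds go, it is also open how a longer chain, such as ethyl or propyl, on that oxygen would compare with methyl and oxolan-3-yl.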